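Chloro for Trifluoromethoxy in a Series Sitting at the Limit

The source may report more compounds than this note shows. Statements on the series, on what has been measured and on what is new or still open speak of the compounds shown alone.

Compound 3 `O=S(=O)(NC1=NCCN1C(=S)SN1CCn2c1nsc2=S)c1ccc(OC(F)(F)F)cc1` carries a trifluoromethoxy group on an aromatic carbon. In a functional assay on KYSE-510 cells (Homo sapiens) for antiproliferative activity, read by crystal violet staining, with a stated time of 96 h (a higher number here means a weaker inhibitor of growth, a lower number a stronger inhibitor of growth), compound 3 gives only a limit, >= 20000 nM. Its two measured neighbours stand the same way. Compound 1 `COc1ccc(S(=O)(=O)NC2=NCCN2C(=S)SN2CCn3c2nsc3=S)cc1` gives a limit in this assay, >= 20000 nM. Compound 2 `COc1ccc(S(=O)(=O)NC2=NCCN2C(=S)SN2CCn3c2nsc3=S)cc1OC` likewise gives a limit in this assay, >= 20000 nM. The step from compound 1 to compound 2 is a step that the two limits leave unreadable from compound 1 to compound 2, and the step from compound 1 to compound 3 is a step that the two limits leave unreadable from compound 1 to compound 3; because of the limit of >= 20000 nM in this assay, at which 3 of the 3 values shown sit, neither can be read for size or direction. Compound 4 `O=S(=O)(NC1=NCCN1C(=S)SN1CCn2c1nsc2=S)c1ccc(Cl)cc1` differs from compound 3 by chloro in place of trifluoromethoxy on an aromatic carbon. Going by the values given here, no measured step bears directly on this exchange, and all three neighbours sit at the limit, so nothing points to a step beyond the scatter in this assay in either direction. For compound 4 in this assay the expected value is 20000 nM, within 8000 nM to 50000 nM. The estimated step is a number no higher from compound 3 to compound 4 (the limit leaves the size open), expected to stay within the scatter.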

Compound 4, concentration for 50% growth inhibition: >= 20000 nM
Compound 4: no number, only a limit; the forecaster's own chance of this, stated with the estimate: 80%; the middle value lies on the limit itself.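

Compound 4 also gives only a limit, so its steps from compound 1, compound 2 and compound 3 cannot be read for size or direction: the limit of >= 20000 nM in this assay, at which 4 of the 4 values shown sit. In this assay the compounds shown leave open whether any of these exchanges on the aromatic ring changes growth inhibition at all.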